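The source may hold more compounds than are shown below. What is called first, only, known or untested is meant among the compounds shown, and "the series" means these compounds.

Measured compounds in the series:

Compound 1, `COc1ccc(/C=C/C(=O)/C=C/c2ccc(OCc3cn(CCCCCOc4cc(=O)oc5ccccc45)nn3)c(OC)c2)cc1`: in a functional assay on COLO 205 cells (Homo sapiens) for inhibition, read by sulforhodamine B assay, with a stated time of 48 h, tested at 50 uM (on this read-out higher numbers stand for more inhibition of growth at the one concentration tested and lower numbers for less inhibition of growth), compound 1 gives 30%.
Compound 2, `COc1ccccc1/C=C/C(=O)/C=C/c1ccc(OCc2cn(CCCCCOc3cc(=O)oc4ccccc34)nn2)c(OC)c1`: compound 2 gives 30%.
Compound 3, `COc1ccccc1/C=C/C(=O)/C=C/c1ccc(OCc2cn(CCOc3cc(=O)oc4ccccc34)nn2)c(OC)c1`: compound 3 gives 67%.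

Compounds 1 and 2 share one core and differ only at the aryl end of the chain: 4-methoxyphenyl in place of 2-methoxyphenyl on a double-bonded chain carbon bound to a double-bonded chain carbon. This change made no change at the digits printed from compound 2 to compound 1 (within the scatter), so the two methoxyphenyl isomers cannot be told apart on this read-out.

Compound 3 carries a different core from compound 2; how the two cores differ is not broken down here. On the values alone, compound 3 stands highest of the three, and its distance to compound 1 and to compound 2 lies beyond the scatter in both cases.

Compound 4, `COc1ccc(/C=C/C(=O)/C=C/c2ccc(OCc3cn(CCOc4cc(=O)oc5ccccc45)nn3)c(OC)c2)cc1`, is to be measured. It is built from compound 3 by the same change as that from compound 2 to compound 1: 4-methoxyphenyl in place of 2-methoxyphenyl on a double-bonded chain carbon bound to a double-bonded chain carbon. The place of the change is the same in both pairs. Among the measured compounds shown here, the only measured example of this change, no change at the digits printed from compound 2 to compound 1 (within the scatter), rests on a single pair and on one core, so its transfer to the core of compound 3 is an assumption, not an established pattern. On that basis the step of a number 2 percentage points lower from compound 3 to compound 4 (within the scatter) is expected to be small, because no change at the digits printed from compound 2 to compound 1 (within the scatter) was within the scatter. Compound 4 is accordingly estimated at 65%, with a range of 45% to 85%.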

Compound 4, percent growth inhibition at one concentration: 68%
The estimate for compound 4 lay 3 percentage points below the measured number, within the range that was stated.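

Read in this assay on the core of compound 3, the replacement of 2-methoxyphenyl by 4-methoxyphenyl on a double-bonded chain carbon bound to a double-bonded chain carbon gives a number 1 percentage points higher from compound 3 to compound 4 (within the scatter) and leaves the read-out effectively unmoved. Set beside the earlier pair, the same change reads alike on both cores: the same change on two cores in this assay, no change at the digits printed (within the scatter) from compound 2 to compound 1 and a number 1 percentage points higher (within the scatter) from compound 3 to compound 4, 1 percentage points apart, within the scatter of two such steps. This shows that, for these two cores, the choice between the two methoxyphenyl isomers does not separate the compounds on this read-out, while the difference in level stays tied to the core; it does not show that the change would stay as small on any further core, in another cell line or at another concentration, and two pairs make a narrow base for any general rule.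

Open, on these data alone, is whether a group other than methoxy at the same aryl end, such as an amine, a carboxylic acid or a plain hydrogen, would also leave the read-out unmoved on either core. Also open, as far as these compounds go, is how the read-out would respond on a core with a longer chain than those seen here, and whether the methoxyphenyl change would stay small there.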